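The source may hold more compounds than are shown below. What is called first, only, known or untested is meant among the compounds shown, and "the series" means these compounds.

Working notes on the hydrazone series.

Compound 1 `O=C(Cc1c[nH]c2ccccc12)N/N=C1\C[C@@H](c2ccc(O)cc2)Oc2cc(O)cc(O)c21` carries the (1H-indol-3-yl)methyl group on a carbonyl carbon whose other neighbour is an amide-type nitrogen. In a functional assay on L5178Y cells (Mus musculus) for inhibition, read by MTT assay, with a stated time of 24 h (a higher number here means a weaker inhibitor, a lower number a stronger inhibitor), compound 1 gives only a limit of the assay, >= 11300 nM. Compound 2 `O=C(N/N=C1\C[C@@H](c2ccc(O)cc2)Oc2cc(O)cc(O)c21)OCc1ccccc1` differs from compound 1 in one place: benzyloxy in place of (1H-indol-3-yl)methyl on a carbonyl carbon. In this assay compound 2 also returns a limit rather than a number, >= 11300 nM. The step that the two limits leave unreadable from compound 1 to compound 2 stays unreadable because the limit of >= 11300 nM in this assay, at which 2 of the 3 values shown sit, covers both ends of it.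

Compound 3 `COc1ccc([C@@H]2C/C(=N\NC(=O)Cc3c[nH]c4ccccc34)c3c(O)cc(OC)cc3O2)cc1` sits on a different core; how it differs from compound 1 is not broken down here. In this assay, among the compounds with values here, compound 3 gives 8600 nM, the single real number in the set so far.

Compound 4 `COc1ccc([C@@H]2C/C(=N\NC(=O)OCc3ccccc3)c3c(O)cc(OC)cc3O2)cc1` stands to compound 3 exactly as compound 2 stands to compound 1: benzyloxy in place of (1H-indol-3-yl)methyl on a carbonyl carbon, the same change at the same kind of carbonyl carbon. Within the data shown here, the one measured instance of this change tells nothing of its size, so any expectation for compound 4 rests on compound 3 alone, whose value 8600 nM is the only real number available. The step from compound 3 to compound 4 is therefore expected to be small, a 1.4-fold higher number from compound 3 to compound 4 (0.14 log units; within the scatter), with a fair chance that only a limit comes back. Compound 4 is estimated at 12000 nM, within 5500 nM to 30000 nM.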

Compound 4, half-maximal inhibitory concentration: > 100000 nM
Compound 4 was reported as a limit (the forecaster's own chance of this, stated with the estimate: 60%); middle value at least 8.3-fold (0.92 log units) away from the limit.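

On the core of compound 3 in this assay, benzyloxy in place of (1H-indol-3-yl)methyl on a carbonyl carbon gives an at least 11-fold higher number from compound 3 to compound 4 (1.06 log units; beyond the scatter), a large step whose far end is a limit of the assay and not a number. The same change on the core of compound 1 cannot be read, because both of its ends sit at a limit: the limit of >= 11300 nM in this assay, at which 2 of the 4 values shown sit. The change therefore has one readable instance, which shows that it can weigh heavily on one core, but not that its size carries over to the other core, although the limits on that core do not contradict such a step.

The compounds shown leave open whether the large step on the core of compound 3 comes from losing (1H-indol-3-yl)methyl or from gaining benzyloxy, since only these two groups appear at this carbonyl carbon. Also open, going by these compounds, is how that core responds to a plain methyl, a longer alkyl chain, or a chain ending in an amine or a carboxylic acid in the same place, and whether any of these gives a real number on the core of compound 1.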